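Thiazole carboxylic acid replacing the benzoic acid amide

The compounds below may be only part of what the source reports. "The series", "measured", "known", "first", "only" and "open" are said of these compounds alone.

Two members of the series have been measured so far. Compound 1 `COc1ccc(-c2nc3cc(F)c(F)cc3n2[C@H](C(=O)N[C@H]2CC[C@H](C(=O)O)CC2)C2CCCCC2)c(Cl)n1` gives in a functional assay for agonist activity at Bile acid receptor (Homo sapiens), read by a luciferase reporter (a higher number here means a larger maximal response, a lower number a smaller maximal response), a value of 21%. Compound 2 `O=C(O)c1cccc(NC(=O)C(C2CCCCC2)n2c(-c3ccc(Cl)cc3)nc3cc(F)c(F)cc32)c1` gives in this assay a value of 14%. Compound 2 thus carries the smaller of the two numbers, but its gap to compound 1 lies within the usual scatter, so the two are not distinguished by these data. Among the compounds with values here, no step between compounds that differ in one place is available, and compound 1 and compound 2 differ in more than one place, so the change to compound 3 cannot be read from a parallel example.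

Compound 3 `Cc1nc(NC(=O)C(C2CCCCC2)n2c(-c3ccc(Cl)cc3)nc3cc(F)c(F)cc32)sc1C(=O)O` has not yet been measured. It differs from compound 2 in one place: 5-carboxy-4-methyl-1,3-thiazol-2-yl in place of 3-carboxyphenyl on an amide-type nitrogen. Nothing in the measured pair tells how an exchange of this kind on the amide-type nitrogen moves the maximal response, so the expected step of a number 1 percentage points higher from compound 2 to compound 3 (within the scatter) is none beyond the scatter. For compound 3 in this assay the estimate is 15%, in the range 5% to 30%.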

Compound 3, largest response reached (reported as efficacy), in percent of the reference or control that the assay uses: 10%
The estimate for compound 3 lay 5 percentage points above the measured number; low and high end bracket the measured number.
By their numbers in this assay, from the lowest: compounds 3, 2 and 1 (each within the scatter of the next, the first and the last beyond it).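

Within the data shown here, this is the first one-place step at the amide-type nitrogen: in this assay the exchange of 3-carboxyphenyl for 5-carboxy-4-methyl-1,3-thiazol-2-yl reads a number 4 percentage points lower from compound 2 to compound 3 (within the scatter) and so does not separate the two groups. The position therefore accepts a change from a six-membered aromatic ring of carbon only to a five-membered aromatic ring with 2 hetero atoms, with the heavy-atom count unchanged at 9 and the hydrogen-bond acceptors going from 1 to 3, without a step beyond the scatter in the maximal response. No information on the cause of this outcome is at hand.

Among these compounds, the single step cannot show what the methyl group and the thiazole ring each contribute, so a 5-carboxy-1,3-thiazol-2-yl group without the methyl remains the open comparison on this nitrogen. Also open, on these data alone, is whether the carboxylic acid itself is needed on this ring, a question that a primary carboxamide or a tetrazole in its place would address, and whether any group here can lift the response beyond the scatter.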